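Moving the trifluoromethyl group around the phenyl ring

The source may hold more compounds than are shown below. What is called first, only, known or untested is meant among the compounds shown, and "the series" means these compounds.

Measured compounds:
Compound 1 `CCC1C(=O)N(C)c2cnc(Nc3ccc(S(N)(=O)=O)cc3)nc2N1C` gives 479 nM in an assay on Sf9 cells for inhibition of serine/threonine-protein kinase 4 (Homo sapiens), read by luminescence and ADP-Glo, with a stated time of 1 h, in the presence of a further agent that is not named here; a lower number here means a stronger inhibitor, a higher number a weaker inhibitor.
Compound 2 `CC(C)C1C(=O)N(C)c2cnc(Nc3ccc(S(N)(=O)=O)cc3)nc2N1C` gives 254 nM in this assay.
Compound 3 `CN1C(=O)C(c2cccc(C(F)(F)F)c2)N(C)c2nc(Nc3ccc(S(N)(=O)=O)cc3)ncc21` gives 2710 nM in this assay.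

Compound 3 stands highest of the three numbers, so it is the weakest inhibitor of the set: a 5.7-fold higher number from compound 1 to compound 3 (0.75 log units; beyond the scatter) and an 11-fold higher number from compound 2 to compound 3 (1.03 log units; beyond the scatter), both beyond the scatter. Compound 4 `CN1C(=O)C(c2ccccc2C(F)(F)F)N(C)c2nc(Nc3ccc(S(N)(=O)=O)cc3)ncc21` keeps every atom of compound 3 but joins them differently: 2-(trifluoromethyl)phenyl in place of 3-(trifluoromethyl)phenyl on a saturated ring carbon.

Neither measured step bears directly on this change. The steps from compound 1 and compound 2 to compound 3 describe swapping an alkyl group for an aryl group, and the step from compound 1 to compound 2 describes a change within an alkyl chain; none moves a substituent around an aromatic ring. With no guide of that kind, the expectation for compound 4 is a number close to that of compound 3, with a wide range, so the expected step is a 1.0-fold lower number from compound 3 to compound 4 (0.00 log units; within the scatter). Compound 4 is therefore estimated at 2700 nM in this assay, between 900 nM and 8000 nM.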

Compound 4, half-maximal inhibitory concentration: 56 nM
Estimate against measurement, compound 4: 48-fold (1.68 log units) above; measured number below the stated range.
By their numbers in this assay, from the lowest: compound 4; then compounds 2 and 1 (each within the scatter of the next); then compound 3.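

In this assay, where the trifluoromethyl group sits on the phenyl ring matters greatly at this saturated ring carbon: the same atoms, joined differently, give a 48-fold lower number from compound 3 to compound 4 (1.68 log units; beyond the scatter). An aryl group here is therefore not a poor replacement for an alkyl group in general, as the 3-(trifluoromethyl)phenyl of compound 3 alone had suggested: the 2-(trifluoromethyl)phenyl group gives a 4.5-fold lower number from compound 2 to compound 4 (0.66 log units; beyond the scatter) and an 8.6-fold lower number from compound 1 to compound 4 (0.93 log units; beyond the scatter), which makes compound 4 the strongest inhibitor of the four. Nothing available explains why moving this group has so large an effect.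

Still open, from the compounds shown here alone, is how a plain phenyl group with no substituent would compare at this carbon. Going by these compounds, it is also open whether a chlorine atom or a methoxy group in place of the trifluoromethyl group would keep the low number of compound 4.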